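A few compounds are considered here, and "the series" means these few. Any claim that something is new, unique, unknown or untested is made for them only; others in the source may bear on it.

Three compounds have been made here, all intended for a functional assay on SEM cells (Homo sapiens) for antiproliferative activity, with a stated time of 72 h; on this read-out lower numbers stand for an effect already at smaller amounts and higher numbers for an effect only at larger amounts of compound. Compound 1 `COc1ccc(-c2cc(=O)c3c(OC)cc(OC)cc3n2S(=O)(=O)c2cccc(Br)c2)cc1` was not taken through this assay, and for compound 1 the entry reads "not determined" (no result reported), so no result exists for it. Compound 2 `COC(=O)c1cc(=O)c2cc(NC(=O)Nc3ccc(Cl)c(C(F)(F)F)c3)ccc2[nH]1` shares its core with the compounds that follow; in this assay compound 2 gives > 6350 nM, which is a limit of the assay rather than a measured number. Compound 3 `COC(=O)c1cc(=O)c2cc(NC(=O)Nc3ccc(F)c(Cl)c3)ccc2[nH]1` keeps the same core and differs only in the group at one end; in this assay compound 3 also reaches only > 6350 nM, again a limit and not a number. Going by the values given here, compound 3 therefore stands at the edge of what this assay reports, sharing that position with compound 2, while compound 1 contributes no value at all; the only evidence the numbers give is the limit of > 6350 nM in this assay, at which 2 of the 3 values shown sit.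

Compound 4 `COC(=O)c1cc(=O)c2cc(NC(=O)NCc3ccccc3)ccc2[nH]1` is the untested one. It differs from compound 3 by benzyl in place of 3-chloro-4-fluorophenyl on an amide-type nitrogen. Among the compounds with values here, no step between measured compounds is at hand to set the size of the change; both measured neighbours stop at a limit. With nothing pointing to a gain, compound 4 is expected to stay near that limit, and the expected step that the limit leaves unreadable from compound 3 to compound 4 amounts to no change beyond the usual scatter. The estimate for compound 4 is 10000 nM, within a range from 3000 nM to 40000 nM, and the assay would most likely again return only a limit.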

Compound 4, half-maximal effective concentration: > 19500 nM
Compound 4 gave a limit, no number (the forecaster's own chance of this, stated with the estimate: 75%); middle value at least 1.9-fold (0.29 log units) away from the limit.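

Compound 3 and compound 4 both end in a limit rather than a number in this assay, so the size of the step between them cannot be read. The compounds shown leave open whether any change on the shared core gives a measurable antiproliferative effect, and how benzyl and 3-chloro-4-fluorophenyl truly compare.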